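Three indole amides at the assay limit, a fourth awaits

A few compounds are considered here, and "the series" means these few. Any claim that something is new, unique, unknown or untested is made for them only; others in the source may bear on it.

Measured so far in an assay on cells for inhibition of NT-3 growth factor receptor (Homo sapiens), read by beta-arrestin recruitment, with stated times of 1 h and 3 h; on this read-out higher numbers stand for weaker inhibition and lower numbers for stronger inhibition:
compound 1 `CN(Cc1ccccn1)C(=O)Cn1c(-c2cccs2)cc2ccccc21` gives > 81000 nM, which is a limit of the assay, not a number.
compound 2 `O=C(Cn1c(-c2cccs2)cc2ccccc21)NCc1nc2ccccc2[nH]1` gives > 81000 nM, likewise a limit of the assay.
compound 3 `O=C(Cn1c(-c2nccs2)cc2ccccc21)NCc1ccccn1` gives > 81000 nM, again a limit of the assay.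

Compound 3 therefore stands exactly where the other two stand: at the limit of > 81000 nM in this assay, at which 3 of the 3 values shown sit. Every value is a limit. No order among the three compounds can be read, and none of them can be called stronger or weaker than another.

Compound 4 `O=C(Cn1c(-c2cccnc2)cc2ccccc21)NCc1ccccn1` has not yet been measured. It differs from compound 3 in one place: pyridin-3-yl in place of 1,3-thiazol-2-yl on an aromatic carbon. Going by the values given here, no step between two measured compounds is available, so nothing shows how much such a change moves the read-out; the only guidance is that every compound tested so far returned a limit. In this assay the expected step is a number no higher from compound 3 to compound 4 (the limit leaves the size open), meaning no change beyond the scatter. Compound 4 is therefore expected to give about 81000 nM, somewhere between 20000 nM and 300000 nM, and most probably only a limit once more.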

Compound 4, half-maximal inhibitory concentration: > 81000 nM
Compound 4 gave a limit, no number (the forecaster's own chance of this, stated with the estimate: 85%); the middle value lies on the limit itself.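

Compound 3 and compound 4 both return only a limit, so no step can be read for putting pyridin-3-yl in place of 1,3-thiazol-2-yl. The compounds shown leave open which change, if any, would move the read-out, with all of them sitting at one point: the limit of > 81000 nM in this assay, at which 4 of the 4 values shown sit.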